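Removing Both Chlorines From the Most Potent Analogue

The compounds below may be only part of what the source reports. "The series", "measured", "known", "first", "only" and "open" are said of these compounds alone.

Of the compounds shown here, three have been measured in a functional assay on HCT-116 cells (Homo sapiens) for antiproliferative activity, read by MTT assay, with a stated time of 72 h; on this read-out higher numbers stand for weaker inhibition and lower numbers for stronger inhibition. Compound 1 `NC1=NC2(CCOCC2)N(OCCCOc2ccc(Cl)cc2)C(N)=N1` gives 690 nM, compound 2 `NC1=NC2(CCOCC2)N(OCCCOc2cccc(Cl)c2Cl)C(N)=N1` gives 5 nM, and compound 3 `COc1ccc(OCCCON2C(N)=NC(N)=NC23CCSCC3)cc1` gives 70 nM. Compound 2 therefore stands lowest of the three numbers, beyond the scatter from both of the others: compound 3 lies nearest to it and compound 1 furthest.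

Among the compounds with values here, the only single-point step among the measured compounds is a 140-fold lower number from compound 1 to compound 2 (2.14 log units; beyond the scatter), a large change brought about by 2,3-dichlorophenyl in place of 4-chlorophenyl on an oxygen on a saturated carbon. Compound 3 differs from compound 2 in more than one place, so its value speaks only for itself.

Compound 4 `NC1=NC2(CCOCC2)N(OCCCOc2ccccc2)C(N)=N1` is not yet measured. It differs from compound 2 as phenyl in place of 2,3-dichlorophenyl on an oxygen on a saturated carbon. This step removes the two chlorines whose arrival, in the step from compound 1, went with the large drop in number. On that basis a large rise in number is expected for compound 4, giving a step of a 100-fold higher number from compound 2 to compound 4 (2.00 log units; beyond the scatter). The estimate for compound 4 in this assay is 500 nM, with a range from 100 nM to 3000 nM.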

Compound 4, half-maximal inhibitory concentration: 6010 nM
Estimate against measurement, compound 4: 12-fold (1.08 log units) below; the measured number lies above the stated range.
By their numbers in this assay, from the lowest: compound 2; then compound 3; then compound 1; then compound 4.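

In this assay, the bare phenyl on this oxygen gives the highest number of the three groups compared on the shared core, with a 1200-fold higher number from compound 2 to compound 4 (3.08 log units; beyond the scatter), so the 2,3-dichlorophenyl group now has an unsubstituted baseline to be judged against. The single chloro of the 4-chlorophenyl group also counts, since hydrogen in its place gives an 8.7-fold higher number from compound 1 to compound 4 (0.94 log units; beyond the scatter), which means that both chlorine-bearing rings in this series sit lower than phenyl, though by very different amounts. No measured information is available to explain why this ring has such a strong hold on the number.

Compounds 1 and 2 differ both in how many chlorines they carry and in where those chlorines stand, so the compounds shown cannot say which of the two matters more. A bromo or a methyl group on the same ring would help show whether the drop in number belongs to chlorine itself or would also appear with another group in its place.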